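This account rests on a few compounds, and the source may have more. Where it says the series, first, only, none or still open, it means among the compounds named here.

Compounds 1 and 2 share one core and differ only in the aromatic group attached to a saturated ring carbon. Compound 1, `C=CC1=C(C(=O)Nc2ccccc2)C(c2ccc(Cl)c(Cl)c2)OC1`, carries a 3,4-dichlorophenyl group there. In a functional assay on QGY7701 cells (Homo sapiens) for cytotoxicity, read by MTT assay, with a stated time of 24 h (a lower number here means a stronger inhibitor, a higher number a weaker inhibitor), compound 1 reaches only the limit of the measurement, > 100000 nM. Compound 2, `C=CC1=C(C(=O)Nc2ccccc2)C(c2ccc(OC)cc2)OC1`, carries a 4-methoxyphenyl group in its place. In this assay compound 2 likewise stops at a limit, > 100000 nM. The step that the two limits leave unreadable from compound 1 to compound 2 cannot be read, because the limit of > 100000 nM in this assay, at which 2 of the 2 values shown sit, is where both values sit. Going by the values given here, compound 2 thus stands at a limit with no number of its own, and the only other value shown is also a limit.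

Compound 3, `C=CC1=C(C(=O)Nc2ccccc2)C(c2ccc(OC)c(OC)c2)OC1`, differs from compound 2 in a single place: methoxy in place of hydrogen on an aromatic carbon. Among the compounds with values here, the one measured step bears on this only by showing that exchanging one aromatic group for another left both compounds at the limit, so neither a direction nor a size can be drawn from it. Compound 3 is therefore expected to stay weak, with an estimated step that the limit leaves unreadable from compound 2 to compound 3 lying within the scatter. Compound 3 is estimated at 150000 nM, within the range 50000 nM to 500000 nM, and is most likely to be reported only as a limit.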

Compound 3, half-maximal inhibitory concentration: > 100000 nM
Compound 3: a limit, no number; the forecaster's own chance of this, stated with the estimate: 80%; the middle value is on the limit's open side.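

Going by these compounds alone, no step from compound 2 to compound 3 can be read, because both stop at the same point: the limit of > 100000 nM in this assay, at which 3 of the 3 values shown sit. As far as these compounds go, what stays open is whether methoxy in place of hydrogen on an aromatic carbon, or any exchange of the aromatic group, changes the result for the shared core in this assay at all.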